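The source may hold more compounds than are shown below. What is called first, only, known or untested is meant among the compounds shown, and "the series" means these compounds.

Three compounds share one core, differing only in the group on the carbonyl carbon. Compound 1 `COc1ccc(CN(C(=O)C2CC2)c2cc(OC)c(OC)c(OC)c2)cc1O` carries cyclopropyl there and gives 59 nM in a functional assay on MGC-803 cells (Homo sapiens) for inhibition, read by MTT assay, with a stated time of 48 h; a lower number here means a stronger inhibitor, a higher number a weaker inhibitor. Compound 2 `C/C=C/C=C/C(=O)N(Cc1ccc(OC)c(O)c1)c1cc(OC)c(OC)c(OC)c1` carries penta-1,3-dien-1-yl and gives 140 nM. Compound 3 `C=C(C)C(=O)N(Cc1ccc(OC)c(O)c1)c1cc(OC)c(OC)c(OC)c1` carries 1-methylethenyl and gives 390 nM, the highest number of the three, with a 6.6-fold higher number from compound 1 to compound 3 (0.82 log units; beyond the scatter) and a 2.8-fold higher number from compound 2 to compound 3 (0.44 log units; beyond the scatter). Compound 4 `COc1ccc(CN(C(=O)/C=C/CBr)c2cc(OC)c(OC)c(OC)c2)cc1O` is not yet measured; it differs from compound 3 by 3-bromoprop-1-en-1-yl in place of 1-methylethenyl on a carbonyl carbon. Both measured steps at this position bear on the change: a 2.4-fold higher number from compound 1 to compound 2 (0.38 log units; beyond the scatter) and a 2.8-fold higher number from compound 2 to compound 3 (0.44 log units; beyond the scatter) show that exchanging the group on the carbonyl carbon moves the number by modest amounts only. The entering 3-bromoprop-1-en-1-yl is a chain with one double bond outside aromatic rings, as is the penta-1,3-dien-1-yl of compound 2, whereas the leaving 1-methylethenyl is the group of the weakest compound measured. A modest lowering of the number is therefore expected, a 2.0-fold lower number from compound 3 to compound 4 (0.29 log units; within the scatter), because compound 2 gives 140 nM. Compound 4 is estimated at 200 nM, between 80 nM and 500 nM.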

Compound 4, half-maximal inhibitory concentration: 71 nM
Estimate against measurement, compound 4: 2.8-fold (0.45 log units) above; the whole stated range lies above it.
By their numbers in this assay, from the lowest: compounds 1, 4 and 2 (each within the scatter of the next, the first and the last beyond it); then compound 3.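

In this assay, 3-bromoprop-1-en-1-yl in place of 1-methylethenyl gives a 5.5-fold lower number from compound 3 to compound 4 (0.74 log units; beyond the scatter) on a carbonyl carbon, with one double bond outside aromatic rings in both groups, so that count does not separate the two. The other two steps are within the scatter, a 2.0-fold lower number from compound 2 to compound 4 (0.29 log units; within the scatter) and a 1.2-fold higher number from compound 1 to compound 4 (0.08 log units; within the scatter), which puts the bromine-bearing chain level with both penta-1,3-dien-1-yl and cyclopropyl, even though those two groups are separated by a 2.4-fold higher number from compound 1 to compound 2 (0.38 log units; beyond the scatter). Nothing shown explains these differences.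

Whether the bromine or the chain itself accounts for the step stays open: plain prop-1-en-1-yl, or chloromethyl or an amine in place of bromomethyl, would separate the two. Also open, going by these compounds, is whether these steps hold on any core other than the shared one.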